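The compounds below may be only part of what the source reports. "The series", "measured", "known", "first", "only" and "open" are said of these compounds alone.

Measured so far in an assay on membranes from HeLa cells for displacement of a labelled ligand from adenosine receptor A3 (Homo sapiens), read by scintillation counting, with a stated time of 180 min, tested at 1 uM; a lower number here means less inhibition, a higher number more inhibition at the concentration tested (going by the name of the read-out):
- compound 1 `CC1=C(C(=O)OCc2ccccc2)C(c2ccco2)NC(=O)N1`: 3%
- compound 2 `CC1=C(C(=O)OCc2ccccc2)C(c2ccoc2)NC(=O)N1`: 1%
- compound 3 `CC1=C(C(=O)OCc2ccccc2)C(c2ccco2)NC(=O)N1C`: 11%

Compound 1 stands second highest of these three numbers, but all three lie close together. Its nearest neighbour is compound 2, with a number 2 percentage points lower from compound 1 to compound 2 (within the scatter); the furthest is compound 3, with a number 8 percentage points higher from compound 1 to compound 3 (within the scatter). Both steps fall within the usual scatter, so the three measured compounds cannot be told apart on these numbers.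

Compound 4 `CC1=C(C(=O)OCC2CCC2)C(c2ccco2)NC(=O)N1` differs from compound 1 in one place: cyclobutyl in place of phenyl on a saturated chain carbon bound to an oxygen next to a carbonyl group. Neither measured step touches this part of the molecule. The step to compound 2 moves the attachment point of the furan ring, and the step to compound 3 adds a methyl to a ring nitrogen; the ester end is unchanged in both. Among the compounds with values here, there is therefore no measured step that bears directly on the change to compound 4.

What the numbers do show is that every variation tried so far has left the inhibition low and within the scatter. On that basis compound 4 is expected to give 4%, with a range of -8% to 18%. This expectation means a step of a number 1 percentage points higher from compound 1 to compound 4 (within the scatter), which is not expected to exceed the scatter.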

Compound 4, a percentage reported as inhibition, at one concentration (the size of the read-out at that concentration, not a potency): 1%
Beside the measured number, compound 4's estimate is 3 percentage points above it; low and high end bracket the measured number.
By their numbers in this assay, from the lowest: compounds 2, 4, 1 and 3 (each within the scatter of the next).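

Within the data shown here, this is the first measured change at this position, on a saturated chain carbon bound to an oxygen next to a carbonyl group: in this assay, cyclobutyl in place of phenyl gives a number 2 percentage points lower from compound 1 to compound 4 (within the scatter). Among these compounds, the six-membered aromatic ring of carbon only and the smaller four-membered non-aromatic ring therefore cannot be told apart here, so this position joins the two places covered by the earlier steps in showing no readable difference. Among the compounds shown here, since all these numbers are low and come from a single concentration, the result says only that neither group brings out measurable inhibition, and no further measurement on hand bears on this change.

Going by these compounds, it remains open whether any group at this position can lift the inhibition clear of the scatter, for example a longer chain, or a chain ending in an amine or a carboxylic acid. Also open, on these data alone, is whether cyclobutyl combined with the methyl on the ring nitrogen of compound 3 would read any differently from either change alone.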